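Weak Starting Point, One Swap, Expectation Kept Modest

The source may hold more compounds than are shown below. What is called first, only, known or untested is meant among the compounds shown, and "the series" means these compounds.

compound 1 `COC(=O)c1scc(-c2ccc(NC(=O)c3ccc(OC)nc3)cc2)c1OC`: 18300 nM
compound 2 `COC(=O)c1scc(-c2ccc(NC(=O)c3ccc(C#N)nc3)cc2)c1OC`: "not determined" (no result reported)

In a functional assay on K562 cells (Homo sapiens) for antiproliferative activity, read by MTT assay, with a stated time of 24 h (a higher number here means a weaker inhibitor, a lower number a stronger inhibitor), compound 1 gives 18300 nM, the only number available, so compound 1 stands alone among the compounds shown. For compound 2 the entry reads "not determined" (no result reported). Compound 3 `COC(=O)c1scc(-c2ccc(NC(=O)c3ccc(C(F)(F)F)cc3)cc2)c1OC` differs from compound 1 in a single place: 4-(trifluoromethyl)phenyl in place of 6-methoxypyridin-3-yl on a carbonyl carbon. Within the data shown here, no measured pair here shows what such a change does, so nothing in the data sets a direction. The step of a 1.2-fold lower number from compound 1 to compound 3 (0.09 log units; within the scatter) is expected to stay within the usual scatter, with no clear direction. Compound 3 is expected to give about 15000 nM in this assay, most likely between 5000 nM and 50000 nM.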

Compound 3, half-maximal inhibitory concentration: 9260 nM
Estimate against measurement, compound 3: 1.6-fold (0.21 log units) above; measured number inside the range.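

In this assay, putting 4-(trifluoromethyl)phenyl in place of 6-methoxypyridin-3-yl on a carbonyl carbon gives a 2.0-fold lower number from compound 1 to compound 3 (0.30 log units; within the scatter), so this one exchange of a ring carrying a hetero atom for a carbon-only ring produces no difference that can be told from assay scatter. No available evidence bears on this result.

Going by these compounds, the swap alters the ring and its substituent at once, so their separate contributions remain open. Also open, on these data alone, is whether an amine or a carboxylic acid on that ring would give a step beyond the scatter.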